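The compounds below may be only part of what the source reports. "The series", "measured", "known", "first", "only" and "open" are said of these compounds alone.

Three compounds built on a shared core are followed here. Compound 1, `Fc1ccc(-n2c(S)nnc2Sc2nnc(-c3ccccc3)n2-c2ccccc2)cc1`, carries a fluorophenyl group on one ring nitrogen and links its two ring systems directly through sulfur. In a functional assay on MDA-MB-231 cells (Homo sapiens) for inhibition, read by MTT assay, with a stated time of 48 h (a lower number here means a stronger inhibitor, a higher number a weaker inhibitor), compound 1 gives 29700 nM, a weak result on this scale. Going by these compounds, compound 2, `CC(C)n1c(S)nnc1CSc1nnc(-c2ccccc2)n1-c1ccccc1`, replaces that arrangement with an isopropyl group on the ring nitrogen and inserts a single carbon between the sulfur and the neighbouring ring; in this assay compound 2 gives "not determined" (no result reported), so no single number has been reported for compound 2 and its place on the scale is unknown. Compound 3, `Sc1nnc(CSc2nnc(-c3ccccc3)n2-c2ccccc2)n1-c1ccccc1`, is the next step. The change from compound 2 is phenyl in place of isopropyl on an aromatic nitrogen. With no measured value for compound 2, the size or direction of this step in this assay cannot be read from the data, and nothing beyond the usual scatter can be predicted. Resting only on the weak showing of compound 1 at 29700 nM, compound 3 is expected to lie near 30000 nM, within a range from 8000 nM to 100000 nM.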

Compound 3, half-maximal inhibitory concentration: 8570 nM
For compound 3 the middle estimate is 3.5-fold (0.54 log units) above the measured one; the measured number falls inside the stated range.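

Within the data shown here, compound 2 has no single number in this assay, so no step from it to compound 3 can be read. The compounds shown leave open whether phenyl or isopropyl on the aromatic nitrogen gives the stronger inhibitor, and by how much. No further evidence here helps to explain the result for compound 3.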